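Swapping the diamine chain for chloro on the quinoline core

The source may report more compounds than this note shows. Statements on the series, on what has been measured and on what is new or still open speak of the compounds shown alone.

Compound 3 `CN(C)CCCNc1ccnc2cc(OCc3ccc(F)cc3)ccc12` gives 1280 nM in a functional assay on SK-OV-3 cells (Homo sapiens) for cytotoxicity, read by MTT assay, with a stated time of 48 h (on this read-out higher numbers stand for weaker inhibition and lower numbers for stronger inhibition), the second highest of the three numbers recorded; compound 1 `CN(C)CCNc1ccnc2cc(OCc3ccc(F)cc3)ccc12` gives 890 nM, and the step of a 1.4-fold higher number from compound 1 to compound 3 (0.16 log units; within the scatter) lies within the scatter, while compound 2 `Clc1ccnc2cc(OCc3ccccc3)ccc12` gives 5170 nM. Compound 4 `Fc1ccc(COc2ccc3c(Cl)ccnc3c2)cc1` carries chloro in place of (3-(dimethylamino)propyl)amino on an aromatic carbon. Going by the values given here, no measured step covers this change directly; the only measured step, a 1.4-fold higher number from compound 1 to compound 3 (0.16 log units; within the scatter), concerns the chain length and does not bear on removing the chain. Compound 2, which also carries chloro in place of an amine but lacks the fluorine, shows a weaker result than compound 3. Compound 4 is therefore expected to move toward weaker inhibition, an estimated step of a 3.5-fold higher number from compound 3 to compound 4 (0.55 log units; beyond the scatter). The estimate for compound 4 is 4500 nM, ranging from 1800 nM to 11000 nM.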

Compound 4, half-maximal inhibitory concentration: 2780 nM
For compound 4 the middle estimate is 1.6-fold (0.21 log units) above the measured one; the measured number falls inside the stated range.
By their numbers in this assay, from the lowest: compounds 1 and 3 (each within the scatter of the next); then compounds 4 and 2 (each within the scatter of the next).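

Replacing either amine chain with chloro on this aromatic carbon, opposite the ring nitrogen, gives a 2.2-fold higher number from compound 3 to compound 4 (0.34 log units; beyond the scatter) and a 3.1-fold higher number from compound 1 to compound 4 (0.49 log units; beyond the scatter) and so raises the number only modestly. Fluoro in place of hydrogen on an aromatic carbon gives a 1.9-fold lower number from compound 2 to compound 4 (0.27 log units; within the scatter) and thus has no effect that can be told from the scatter. No measured evidence accounts for the effect of removing the chain.

The compounds shown leave open whether a longer chain, a primary amine or a morpholine ring at this carbon would match the two dimethylamino chains.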